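This account rests on a few compounds, and the source may have more. Where it says the series, first, only, none or still open, it means among the compounds named here.

Compound 1 `CC(=O)Oc1cccc2cc(-c3ccccc3)c(=O)oc12` in an assay on CHO cells for displacement of a labelled ligand from adenosine receptor A3 (Homo sapiens), read by radioligand binding (on this read-out higher numbers stand for weaker inhibition and lower numbers for stronger inhibition), gives 6860 nM. Compound 2 `CC(=O)Oc1ccc2cc(-c3ccccc3)c(=O)oc2c1OC(C)=O` in this assay gives 5170 nM.

Among the measured compounds shown here, of the two numbers measured, compound 2 has the lower one, though the only other compound, compound 1, is separated from it by a 1.3-fold lower number from compound 1 to compound 2 (0.12 log units; within the scatter), a gap within the scatter, so no order between them can be claimed. Compound 3 `CC(=O)Oc1ccc(-c2cc3ccc(OC(C)=O)c(OC(C)=O)c3oc2=O)cc1` has not yet been measured. It differs from compound 2 in one place: acetoxy in place of hydrogen on an aromatic carbon. For the measured compounds named here, the one measured step that bears on this is a 1.3-fold lower number from compound 1 to compound 2 (0.12 log units; within the scatter), where an acetoxy likewise replaced a hydrogen on an aromatic carbon and the number barely moved. On that basis compound 3 is expected to show no step beyond the scatter in this assay, a 1.1-fold lower number from compound 2 to compound 3 (0.06 log units; within the scatter). Compound 3 is therefore estimated at 4500 nM, with a range from 1500 nM to 13000 nM.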

Compound 3, inhibition constant: 6140 nM
Beside the measured number, compound 3's estimate is 1.4-fold (0.13 log units) below it; low and high end bracket the measured number.
By their numbers in this assay, from the lowest: compounds 2, 3 and 1 (each within the scatter of the next).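

In this assay, acetoxy in place of hydrogen on an aromatic carbon of a six-membered aromatic ring of carbon only, para to a large group, gives a 1.2-fold higher number from compound 2 to compound 3 (0.07 log units; within the scatter). The earlier step, a 1.3-fold lower number from compound 1 to compound 2 (0.12 log units; within the scatter), was the same exchange at a different place, so the result extends the finding to a second position: at neither place does this exchange give a step beyond the scatter. Nothing available explains why the number stays within the scatter at either place.

The compounds shown leave open whether a different group at this position, such as an amine, a carboxylic acid or a longer chain, would give a step beyond the scatter. They also leave open whether acetoxy would do so at other places on the phenyl ring or the shared core.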